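A Benzyl-to-Butoxy Change on a Shared Urea Core

The source may hold more compounds than are shown below. What is called first, only, known or untested is meant among the compounds shown, and "the series" means these compounds.

Compound 1 `O=C(Nc1ccccc1OC(F)(F)F)Nc1n[nH]c2ccccc12` gives 17400 nM in a functional assay on UO-31 cells (Homo sapiens) for inhibition, read by sulforhodamine B assay, with a stated time of 48 h; a higher number here means a weaker inhibitor of growth, a lower number a stronger inhibitor of growth. Compound 2 `O=C(Nc1ccc(Cc2ccccc2)cc1)Nc1nn(C(=O)Nc2ccc(Cc3ccccc3)cc2)c2ccccc12` reaches only a limit of the assay, > 100000 nM. Compound 3 `Nc1nn(C(=O)Nc2ccc(Cc3ccccc3)cc2)c2ccccc12` gives 347 nM.

Compound 3 holds the lowest of the two numbers recorded; its nearest neighbour, compound 1, sits far higher, a gap well beyond the scatter. The entry for compound 2 is a limit of > 100000 nM in this assay, at which 1 of the 3 values shown sits, and carries no number. Compound 4 `CCCCOc1ccc(NC(=O)n2nc(N)c3ccccc32)cc1` differs from compound 3 by butoxy in place of benzyl on an aromatic carbon. For the measured compounds named here, no pair differing in one place has been measured, so no step size is known; a modest shift toward a somewhat higher number is expected, one that may stay within the scatter. Compound 4 is estimated at 600 nM (range 150 nM to 3000 nM), an expected step of a 1.7-fold higher number from compound 3 to compound 4 (0.24 log units; within the scatter).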

Compound 4, concentration for 50% growth inhibition: 17500 nM
Compound 4: the middle estimate sits 29-fold (1.46 log units) below what was measured; measured number outside the range, above it.
By their numbers in this assay, from the lowest: compound 3; then compounds 1 and 4 (each within the scatter of the next). At a limit, above all of these: compound 2.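

In this assay, replacing benzyl with butoxy on an aromatic carbon, para to a large group, gives a 50-fold higher number from compound 3 to compound 4 (1.70 log units; beyond the scatter). For the compounds shown here, this is the first measured step at this position, and it shows that the two groups are not interchangeable there in this assay. Nothing among the measurements shown accounts for the size of this step.

The compounds shown leave open whether the step tracks the ring that leaves or the oxygen that enters. They also leave open how a phenoxy group or a plain butyl chain would behave at this position.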